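A few compounds are considered here, and "the series" means these few. Any claim that something is new, unique, unknown or untested is made for them only; others in the source may bear on it.

Measured so far in a functional assay on HCT-116 cells (Homo sapiens) for inhibition, read by MTT assay, with a stated time of 48 h; on this read-out lower numbers stand for stronger inhibition and higher numbers for weaker inhibition:
compound 1, `Brc1cccc(CSc2nnc(-c3ccncc3)n2-c2ccccc2)c1`, 8170 nM
compound 2, `Fc1ccc(CSc2nnc(-c3ccncc3)n2-c2ccccc2)cc1`, 12800 nM
compound 3, `Fc1cccc(F)c1CSc1nnc(-c2ccncc2)n1-c1ccccc1`, 22100 nM

Compound 3 stands at the highest number of the three: a 1.7-fold higher number from compound 2 to compound 3 (0.24 log units; within the scatter), and a 2.7-fold higher number from compound 1 to compound 3 (0.43 log units; beyond the scatter). Compound 4, `O=[N+]([O-])c1cccc(CSc2nnc(-c3ccncc3)n2-c2ccccc2)c1`, differs from compound 3 by 3-nitrophenyl in place of 2,6-difluorophenyl on a saturated chain carbon bound to a sulfur. No measured step carries a nitro group, so the steps that bear on it are the exchanges of the aryl group on the same carbon: a 1.6-fold higher number from compound 1 to compound 2 (0.19 log units; within the scatter) together with the two steps into compound 3 given above. All of these have stayed small. The closest measured point is compound 1, whose 3-bromophenyl also sits on a saturated chain carbon bound to a sulfur, with its value of 8170 nM. A modest lowering back toward that region is expected, a 2.2-fold lower number from compound 3 to compound 4 (0.34 log units; beyond the scatter). Compound 4 is therefore estimated at 10000 nM, with a range from 4000 nM to 30000 nM.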

Compound 4, half-maximal inhibitory concentration: 19800 nM
The estimate for compound 4 lay 2.0-fold (0.30 log units) below the measured number; measured number inside the range.
By their numbers in this assay, from the lowest: compounds 1, 2, 4 and 3 (each within the scatter of the next, the first and the last beyond it).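

In this assay, the 3-nitrophenyl group on a saturated chain carbon bound to a sulfur is not separated from the fluorinated aryl groups: a 1.1-fold lower number from compound 3 to compound 4 (0.05 log units; within the scatter), and a 1.5-fold higher number from compound 2 to compound 4 (0.19 log units; within the scatter). Nitro in place of bromo on an aromatic carbon is a modest step beyond the scatter, a 2.4-fold higher number from compound 1 to compound 4 (0.38 log units; beyond the scatter). The added hydrogen-bond acceptors of the entering group therefore come with no change that can be read against compound 3.

Nothing at hand gives a cause for the gap between compound 1 and compound 4. On these data alone, whether an amine or a carboxylic acid on the aryl ring, or a longer chain at the sulfur, would shift the number remains open.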